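Swapping nitro for chloro on a chalcone amine oxidase inhibitor

A few compounds are considered here, and "the series" means these few. Any claim that something is new, unique, unknown or untested is made for them only; others in the source may bear on it.

Three close relatives sharing one core have been measured in an assay on isolated protein for inhibition of Amine oxidase [flavin-containing] B (Homo sapiens); on this read-out lower numbers stand for stronger inhibition and higher numbers for weaker inhibition. Compound 1 `CCOc1ccc(C(=O)/C=C/c2ccc(CC)cc2)cc1` gives 210 nM, compound 2 `CCOc1ccc(C(=O)/C=C/c2ccc(F)cc2)cc1` gives 53 nM, and compound 3 `CCOc1ccc(C(=O)/C=C/c2ccc([N+](=O)[O-])cc2)cc1` gives 210 nM. Compound 3 therefore stands level with compound 1, the two together showing the highest numbers of the set, while the step of a 4.0-fold higher number from compound 2 to compound 3 (0.60 log units; beyond the scatter) is beyond the scatter. Compound 4 `CCOc1ccc(C(=O)/C=C/c2ccc(Cl)cc2)cc1` is not yet measured; it differs from compound 3 by chloro in place of nitro on an aromatic carbon.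

For the measured compounds named here, two measured steps bear on this change. Going by the values given here, the step of a 4.0-fold lower number from compound 1 to compound 2 (0.60 log units; beyond the scatter) and the step of a 4.0-fold higher number from compound 2 to compound 3 (0.60 log units; beyond the scatter) both show that a fluoro at this position gives a clearly lower number than either an ethyl or a nitro, and these are the only comparisons available. No halogen other than fluoro has been measured, so how far a chloro follows fluoro is uncertain. A step of roughly the size seen for a 4.0-fold higher number from compound 2 to compound 3 (0.60 log units; beyond the scatter), but in the lowering direction, is expected, because a 4.0-fold higher number from compound 2 to compound 3 (0.60 log units; beyond the scatter) marks how much the nitro costs relative to a halogen. Compound 4 is therefore estimated at 70 nM, within the range 25 nM to 200 nM, which means an expected step of a 3.0-fold lower number from compound 3 to compound 4 (0.48 log units; beyond the scatter).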

Compound 4, half-maximal inhibitory concentration: 210 nM
Beside the measured number, compound 4's estimate is 3.0-fold (0.48 log units) below it; measured number outside the range, above it.
By their numbers in this assay, from the lowest: compound 2; then compounds 1, 3 and 4 (each within the scatter of the next).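

The new result separates the two halogens: in this assay, chloro does not share the low number seen with fluoro, and replacing fluoro with chloro gives a 4.0-fold higher number from compound 2 to compound 4 (0.60 log units; beyond the scatter). Chloro instead falls in with the two other groups, with no change at the digits printed from compound 3 to compound 4 (within the scatter) and no change at the digits printed from compound 1 to compound 4 (within the scatter), so nitro, with its 3 heavy atoms and 2 hydrogen-bond acceptors, and chloro, with 1 heavy atom and no acceptors, cannot be told apart here, and compound 2 alone stands out with the lowest number of the four. No supporting data are available to explain why fluoro stands apart from the other three groups at this position.

From the compounds shown here alone, it remains open whether a low number at this position is unique to fluoro, or whether groups such as bromo, methoxy or an amine would match compound 2 rather than compounds 1, 3 and 4. It is also unknown whether the same grouping of these four substituents would hold if the ethoxy group elsewhere on the shared core were replaced by a longer chain.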